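The compounds below may be only part of what the source reports. "The series", "measured", "known", "first", "only" and "open" are said of these compounds alone.

Measured so far in an ADME assay on microsomes from liver (Rattus norvegicus, strain Crj;CD(SD)) for metabolic stability, read by LC-MS, using NADPH, with a stated time of 30 min, tested at 0.1 uM; on this read-out higher numbers stand for a more stable compound and lower numbers for a less stable compound:
Compound 1 `C[C@@]1(c2cc(NC(=O)c3cnc(OCF)cn3)ccc2F)C=C(CF)OC(N)=N1` gives 52%
Compound 2 `Cc1cc(C#N)cnc1C(=O)Nc1ccc(F)c([C@]2(C)C=C(CF)OC(N)=N2)c1` gives 34%
Compound 3 `C[C@@]1(c2cc(NC(=O)c3coc(CF)n3)ccc2F)C=C(CF)OC(N)=N1` gives 39%

Compound 3 at 39% lies within the scatter of compound 2 and under compound 1. Compound 4 `COc1cc(C#N)cnc1C(=O)Nc1ccc(F)c([C@]2(C)C=C(CF)OC(N)=N2)c1` differs from compound 3 by 5-cyano-3-methoxypyridin-2-yl in place of 2-(fluoromethyl)-1,3-oxazol-4-yl on a carbonyl carbon on a carbonyl carbon: 5-cyano-3-methoxypyridin-2-yl in place of 2-(fluoromethyl)-1,3-oxazol-4-yl. Compound 2, with 5-cyano-3-methylpyridin-2-yl at that place, bears most closely, through a number 5 percentage points higher from compound 2 to compound 3 (within the scatter) in the reverse sense. The larger steps of a number 18 percentage points lower from compound 1 to compound 2 (beyond the scatter) and a number 13 percentage points lower from compound 1 to compound 3 (beyond the scatter) start from 5-(fluoromethoxy)pyrazin-2-yl, which compound 4 does not carry. For the measured compounds named here, no measured step compares methoxy with methyl. The expected change is therefore a number 3 percentage points lower from compound 3 to compound 4 (within the scatter) in this assay and no step beyond the scatter is expected. Compound 4 is estimated at 36% with 22% to 52% as the expected range.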

Compound 4, percent of the compound remaining: 60%
Compound 4: middle estimate off by 24 percentage points, on the low side, and the stated range ends below it.
By their numbers in this assay, from the lowest: compounds 2 and 3 (each within the scatter of the next); then compounds 1 and 4 (each within the scatter of the next).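

In this assay, for the compounds shown here, methoxy in place of methyl on an aromatic carbon gives a number 26 percentage points higher from compound 2 to compound 4 (beyond the scatter) as the first direct comparison of these two groups. The 5-cyano-3-methoxypyridin-2-yl group also gives a number 21 percentage points higher from compound 3 to compound 4 (beyond the scatter) against 2-(fluoromethyl)-1,3-oxazol-4-yl, and a number 8 percentage points higher from compound 1 to compound 4 (within the scatter) against 5-(fluoromethoxy)pyrazin-2-yl, so those last two groups cannot be told apart here. Nothing available accounts for the methoxy result. As far as these compounds go, whether ethoxy, hydroxy or an amine on that aromatic carbon would match methoxy remains open, as does how the number would respond without the nitrile.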